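Dimethylamino for Cyano: Cytotoxicity Expected to Stay Low

A few compounds are considered here, and "the series" means these few. Any claim that something is new, unique, unknown or untested is made for them only; others in the source may bear on it.

Compound 3 `N#Cc1ccc(NCc2cncn2Cc2ccc(-c3ccccc3)cc2)cc1-c1ccccc1` is one of three compounds tested in a toxicity assay on NIH3T3 cells (Mus musculus) for cytotoxicity, read by resazurin assay; a lower number here means that less compound is needed, a higher number that more compound is needed for the effect. Compound 3 gives > 1000 nM, which is a limit of the assay and not a number. Compound 2 `N#Cc1ccc(NCc2cncn2Cc2ccc(-c3ccccc3)cc2N)cc1-c1ccccc1` gives > 1000 nM, also a limit. Compound 1 `COC(=O)c1ccc(NCc2cncn2Cc2cccc([N+](=O)[O-])c2)cc1-c1ccccc1` gives > 10000 nM, again a limit. Compound 3 thus sits at the limit of > 1000 nM in this assay, at which 2 of the 3 values shown sit. Compound 1 sits at the limit of > 10000 nM in this assay, at which 1 of the 3 values shown sits. Among the measured compounds shown here, the only one-point change among them is a step that the two limits leave unreadable from compound 2 to compound 3; both of its ends are limits. Compound 4 `CN(C)c1ccc(NCc2cncn2Cc2ccc(-c3ccccc3)cc2)cc1-c1ccccc1` differs from compound 3 by dimethylamino in place of cyano on an aromatic carbon. For the measured compounds named here, no measured step bears on this change, so no direction beyond the scatter can be expected in this assay. Compound 4 is expected to give about 10000 nM, between 1000 nM and 100000 nM, most likely again as a limit. The step that the limit leaves unreadable from compound 3 to compound 4 is therefore expected to be small.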

Compound 4, half-maximal effective concentration: > 1000 nM
Compound 4: no number, only a limit; the forecaster's own chance of this, stated with the estimate: 80%; the middle value is on the limit's open side.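

Compound 3 and compound 4 both give only a limit in this assay, so no size can be read for the step between them. The compounds shown leave open what concentration any of them needs for the half-maximal effect.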